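The source may report more compounds than this note shows. Statements on the series, on what has been measured and on what is new or still open speak of the compounds shown alone.

Measured so far in a functional assay on EC9706 cells (Homo sapiens) for cytotoxicity, read by MTT assay, with a stated time of 72 h; on this read-out lower numbers stand for stronger inhibition and higher numbers for weaker inhibition
- compound 1 `Cc1ccc(NC(=O)CSC(=S)N[C@H]2CCOC2=O)cc1` gives 93900 nM
- compound 2 `CSC(=S)N[C@H]1CCOC1=O` gives > 128000 nM (a limit, not a number)
- compound 3 `O=C(CCl)Nc1ccc(C(=O)/C=C/c2ccc(Cl)cc2)cc1` gives 8340 nM

Of the two actual numbers, compound 3 holds the lower, and the gap up to compound 1 lies beyond the scatter. Compound 4 `O=C(CCl)Nc1ccc(C(=O)/C=C/c2cccc(Cl)c2)cc1` has 3-chlorophenyl in place of 4-chlorophenyl on a double-bonded chain carbon bound to a double-bonded chain carbon. Within the data shown here, no measured pair shows a change of this kind, so the data favour no direction. The step of a 1.1-fold higher number from compound 3 to compound 4 (0.03 log units; within the scatter) is expected to stay within the scatter in this assay (no change of note). For compound 4 the expected value is 9000 nM (estimated range 3500 nM to 24000 nM).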

Compound 4, half-maximal inhibitory concentration: 5560 nM
Beside the measured number, compound 4's estimate is 1.6-fold (0.21 log units) above it; the measured number falls inside the stated range.
By their numbers in this assay, from the lowest: compounds 4 and 3 (each within the scatter of the next); then compound 1. At a limit, above all of these: compound 2.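

In this assay, 3-chlorophenyl in place of 4-chlorophenyl on a double-bonded chain carbon bound to a double-bonded chain carbon gives a 1.5-fold lower number from compound 3 to compound 4 (0.18 log units; within the scatter). Among these compounds, this is the first single-place step, and at this place the two chlorophenyl isomers read alike. No available evidence bears on this step.

Open, as far as these compounds go, is whether an unsubstituted phenyl, or a methoxy group or carboxylic acid in place of the chlorine, would read alike too. Also open, from the compounds shown here alone, is how any other part of the core of compound 4 bears on the number.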